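This account rests on a few compounds, and the source may have more. Where it says the series, first, only, none or still open, it means among the compounds named here.

In a functional assay on A549 cells (Homo sapiens) for antiproliferative activity, read by MTT assay, with a stated time of 48 h (on this read-out higher numbers stand for weaker inhibition and lower numbers for stronger inhibition), compound 1 (`C/C(=C\CC/C(C)=C/CC[C@@H]1[C@@]2(C)CCC(=O)C(C)(C)[C@H]2CC[C@@]1(C)O)CC/C=C(\C)C(=O)OCc1cn(-c2ccc([N+](=O)[O-])cc2)nn1`) reads > 150000 nM, which is a limit. Compound 2 (`C/C(=C\CC/C(C)=C/CC[C@@H]1[C@@]2(C)CCC(=O)C(C)(C)[C@H]2CC[C@@]1(C)O)CC/C=C(\C)C(=O)OCc1cn(-c2ccccc2[N+](=O)[O-])nn1`) reads > 150000 nM, also a limit. Compound 3 (`COc1cccc(-n2cc(COC(=O)/C(C)=C/CC/C(C)=C/CC/C(C)=C/CC[C@@H]3[C@@]4(C)CCC(=O)C(C)(C)[C@H]4CC[C@@]3(C)O)nn2)c1`) reads > 150000 nM, again a limit and not a number. Within the data shown here, the series so far stands at the limit of > 150000 nM in this assay, at which 3 of the 3 values shown sit. Compound 4 (`C/C(=C\CC/C(C)=C/CC[C@@H]1[C@@]2(C)CCC(=O)C(C)(C)[C@H]2CC[C@@]1(C)O)CC/C=C(\C)C(=O)OCc1cn(-c2cccc(O)c2)nn1`) differs from compound 3 as follows: hydrogen in place of methyl on an oxygen on an aromatic ring, that is, methoxy to hydroxy, 3-methoxyphenyl to 3-hydroxyphenyl. Among the measured compounds shown here, two measured steps bear on this group: a step that the two limits leave unreadable from compound 1 to compound 3 and a step that the two limits leave unreadable from compound 2 to compound 3. Neither gives a size or a direction to carry over. No change beyond the scatter is expected, and the estimated step is a step that the limit leaves unreadable from compound 3 to compound 4. For compound 4 the estimate is 170000 nM, with an expected range from 80000 nM to 300000 nM.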

Compound 4, half-maximal inhibitory concentration: 42800 nM
For compound 4 the middle estimate is 4.0-fold (0.60 log units) above the measured one, and the stated range ends above it.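

Methoxy to hydroxy on the aromatic ring gives the first readable change in this assay: an at least 3.5-fold lower number from compound 3 to compound 4 (0.54 log units; beyond the scatter). The 3-hydroxyphenyl group also reads against both nitrophenyl groups, with an at least 3.5-fold lower number from compound 2 to compound 4 (0.54 log units; beyond the scatter) and an at least 3.5-fold lower number from compound 1 to compound 4 (0.54 log units; beyond the scatter). The steps among compound 1, compound 2 and compound 3 cannot be read, and compound 4 alone gives a number rather than a limit: the limit of > 150000 nM in this assay, at which 3 of the 4 values shown sit.

Going by these compounds, the true size of these steps stays open, as each rests on a limit. Also open, on these data alone, is whether an amine or a carboxylic acid in place of the hydroxy would keep the lower number.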